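The source may hold more compounds than are shown below. What is called first, only, known or untested is meant among the compounds shown, and "the series" means these compounds.

Compound 1 `N#Cc1ccc(N2CCN(C(=S)SCc3ccc(C(=O)Nc4ccccc4N)cc3)CC2)cc1` and compound 2 `Cc1ccc(N2CCN(C(=S)SCc3ccc(C(=O)Nc4ccccc4N)cc3)CC2)cc1` share one core and differ only in the group on the aromatic carbon. In a functional assay on MGC-803 cells (Homo sapiens) for antiproliferative activity, read by CCK-8 assay, with a stated time of 72 h, tested at 2 uM (a higher number here means a stronger effect of the compound at the concentration tested, a lower number a weaker effect), compound 1 gives 34.5%, and compound 2 gives 33.4%. Within the data shown here, the only measured step, a number 1.1 percentage points lower from compound 1 to compound 2 (within the scatter), is within the scatter, so compound 2 stands at the lower of the two numbers without standing apart from compound 1.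

Compound 3 `Nc1ccccc1NC(=O)c1ccc(CSC(=S)N2CCN(Cc3ccccc3)CC2)cc1` differs from compound 2 in a different place: benzyl in place of 4-methylphenyl on an amine nitrogen in a ring. The ring nitrogen that carries the 4-methylphenyl group in compound 2 carries a benzyl group in compound 3. Among the measured compounds shown here, no measured step touches this position; the one step on record, from a cyano to a methyl on the aromatic carbon, was within the scatter and gives no guide for a change at the ring nitrogen. The expectation for this assay is therefore a step of uncertain direction, a number 3.4 percentage points lower from compound 2 to compound 3 (within the scatter), not clearly beyond the scatter, with a wide range. Compound 3 is estimated at 30%, with a range from 12% to 48%.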

Compound 3, a percentage reported as inhibition, at one concentration (the size of the read-out at that concentration, not a potency): 18.1%
Estimate against measurement, compound 3: 11.9 percentage points above; measured number inside the range.
By their numbers in this assay, from the lowest: compound 3; then compounds 2 and 1 (each within the scatter of the next).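

In this assay, the ring nitrogen proves to be a place where the read-out moves: benzyl in place of 4-methylphenyl on this amine nitrogen in a ring gives a number 15.3 percentage points lower from compound 2 to compound 3 (beyond the scatter), and benzyl in place of 4-cyanophenyl gives a number 16.4 percentage points lower from compound 1 to compound 3 (beyond the scatter), whereas the earlier change from cyano to methyl on the aromatic carbon stayed within the scatter. The step from 4-methylphenyl to benzyl comes with no change in the atoms themselves, since the two groups have the same atoms, joined differently, so a rearrangement alone is enough to go with a step beyond the scatter. Nothing on hand accounts for this drop.

The compounds shown leave open whether the lower number follows from the single carbon that sets the ring of benzyl apart from the ring nitrogen or from something else about this group. A longer chain such as 2-phenylethyl, a benzoyl group or a plain methyl on the same nitrogen could tell whether such compounds fall with compound 3 or stay with compound 1 and compound 2.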